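Branching the Sulfonyl Chain on a Shared Core

The source may report more compounds than this note shows. Statements on the series, on what has been measured and on what is new or still open speak of the compounds shown alone.

Compound 1 `CN(c1cccc2c1CCCC2c1c[nH]cn1)S(C)(=O)=O` gives 708 nM in an assay on isolated protein for binding affinity to Alpha-1D adrenergic receptor (Rattus norvegicus), read by radioligand binding; on this read-out higher numbers stand for weaker inhibition and lower numbers for stronger inhibition.
Compound 2 `CCCS(=O)(=O)Nc1cccc2c1CCCC2c1c[nH]cn1` gives < 10000 nM in this assay, a limit of the assay rather than a number.

Compound 2 therefore stands only at a limit, and the limit of < 10000 nM in this assay, at which 1 of the 2 values shown sits, leaves a step that the limit leaves unreadable from compound 1 to compound 2 unreadable. Compound 3 `CC(C)S(=O)(=O)Nc1cccc2c1CCCC2c1c[nH]cn1` differs from compound 2 by isopropyl in place of propyl on a sulfonyl sulfur. Among the measured compounds shown here, no measured step bears on this change, so the size of the step in this assay is open in either direction. Compound 3 is nonetheless expected near 3000 nM, within 500 nM to 10000 nM. The expected step from compound 2 is a step that the limit leaves unreadable from compound 2 to compound 3.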

Compound 3, inhibition constant: 2040 nM
Beside the measured number, compound 3's estimate is 1.5-fold (0.17 log units) above it; the range from low to high includes it.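

Compound 3 puts a number rather than a limit on a sulfonamide without the nitrogen methyl: in this assay, the change in the sulfonamide gives a 2.9-fold higher number from compound 1 to compound 3 (0.46 log units; beyond the scatter). Compound 2 remains a limit and not a number, so the steps that involve compound 2 cannot be read, and propyl and isopropyl on the sulfonyl sulfur cannot be ranked: the limit of < 10000 nM in this assay, at which 1 of the 3 values shown sits.

The compounds shown leave open how a cyclopropyl group or a longer chain on the sulfonyl sulfur would read, and whether a methyl on the sulfonamide nitrogen of compound 3 would shift its value.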